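A few compounds are considered here, and "the series" means these few. Any claim that something is new, unique, unknown or untested is made for them only; others in the source may bear on it.

For the measured compounds named here, only two compounds have numbers so far in a functional assay on HeLa cells (Homo sapiens) for cytotoxicity, read by XTT assay, with a stated time of 72 h; on this read-out higher numbers stand for weaker inhibition and lower numbers for stronger inhibition. Compound 1 `COc1ccc(C(=O)c2cc(OC)c(OC)c(OC)c2)cc1[N+](=O)[O-]` gives 2500 nM, while compound 2 `COc1ccc(Cc2ccc3ccccc3c2)c(OC)c1OC` gives 200 nM, the lower of the two numbers and the stronger inhibition, with a gap beyond the scatter. Compound 3 `COc1ccc(C(O)c2ccc3ccccc3c2)c(OC)c1OC` has not yet been measured in this assay. It differs from compound 2 in one place: hydroxy in place of hydrogen on a saturated chain carbon bound to two aromatic carbons. In words, it carries hydroxy in place of hydrogen on a saturated chain carbon bound to two aromatic carbons. Going by the values given here, no measured pair shows what this change does, so the expectation starts from compound 2 at 200 nM, the closest structure with a number. The expected result is a small move towards weaker inhibition, a 1.3-fold higher number from compound 2 to compound 3 (0.11 log units; within the scatter), which would not go beyond the scatter. Compound 3 is estimated at 260 nM, with an expected range from 70 nM to 900 nM.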

Compound 3, half-maximal inhibitory concentration: > 10000 nM
Compound 3 was reported as a limit (the forecaster's own chance of this, stated with the estimate: 5%); middle value at least 38-fold (1.58 log units) away from the limit.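

In this assay, hydroxy in place of hydrogen on a saturated chain carbon bound to two aromatic carbons is far from a small edit: it gives an at least 50-fold higher number from compound 2 to compound 3 (1.69 log units; beyond the scatter). Compound 3 gives > 10000 nM, and this is a limit of the assay, not a number. No earlier pair tested this position, and it now appears that this single change is enough to take inhibition out of the range that this assay can follow: the limit of > 10000 nM in this assay, at which 1 of the 3 values shown sits.

The compounds shown leave open whether this loss is particular to hydroxy or would follow from other groups on the same carbon, such as an amine or a fluorine atom. For the compounds shown here, with only one step at this position, no general rule about the position can yet be drawn.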